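The compounds below may be only part of what the source reports. "The series", "measured", "known", "first", "only" and "open" are said of these compounds alone.

Working notes on the series. Three compounds carry numbers in a functional assay on HEK293 cells for agonist activity at D(4) dopamine receptor (Homo sapiens), read by FLIPR; on this read-out lower numbers stand for smaller maximal responses and higher numbers for larger maximal responses. Compound 1 `Cc1ccc(C(=O)NCN2CCC(c3cccc[n+]3[O-])CC2)cc1C` gives 65%. Compound 2 `Cc1ccc([N+](=O)[O-])cc1NC(=O)CN1CCC(c2cccc[n+]2[O-])CC1` gives 76%. Compound 3 `Oc1ccc(N2CCN(Cc3nc4ccccc4[nH]3)CC2)nc1` gives 70%. Compound 1 holds the lowest of the three numbers; the nearest is compound 3, whose number lies within the scatter of it, so no order between those two is read; the furthest is compound 2, whose number stands beyond the scatter above it.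

Compound 4 `Cc1cc(C(=O)NCN2CCC(c3cccc[n+]3[O-])CC2)ccc1Cl` differs from compound 1 in one place: chloro in place of methyl on an aromatic carbon. Among the compounds with values here, no measured pair differs by a change of this kind, so no measured step sizes it. What leaves and what enters are each a single heavy atom with no donors, no acceptors and no charge. The step expected from this change, a number 2 percentage points lower from compound 1 to compound 4 (within the scatter), is small and of no firm direction, staying around the value of compound 1 in this assay, 65%. For compound 4 the estimate in this assay is 63%, with a range from 42% to 84%.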

Compound 4, largest response reached (reported as efficacy), in percent of the reference or control that the assay uses: 62%
Compound 4: middle estimate off by 1 percentage points, on the high side, within the range that was stated.
By their numbers in this assay, from the lowest: compounds 4, 1, 3 and 2 (each within the scatter of the next, the first and the last beyond it).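

In this assay, the series now has its first measured step between compounds that differ in one place: chloro in place of methyl on an aromatic carbon, para to a large group and ortho to a methyl group, gives a number 3 percentage points lower from compound 1 to compound 4 (within the scatter). At this position, therefore, 3,4-dimethylphenyl and 4-chloro-3-methylphenyl are not told apart by the maximal response, and this single pair gives the change no direction. No available evidence bears on this result.

The compounds shown leave open whether the maximal response at this position also stays put with a group of another kind, such as an amine, a carboxylic acid or a longer chain. They also leave open whether chloro in place of methyl gives a similar step at another aromatic carbon or on another core.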